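Swapping 4-nitrobenzyl for pentyl on the aromatic nitrogen

The source may report more compounds than this note shows. Statements on the series, on what has been measured and on what is new or still open speak of the compounds shown alone.

Compound 1 `CC(=O)c1ccc(-n2cc(COc3ccc(/C=C/C(=O)c4ccc5c(c4O)CCC(C)(C)O5)cc3)nn2)cc1` gives 91400 nM in a functional assay on HepG2 cells (Homo sapiens) for antiproliferative activity, read by MTT assay; on this read-out higher numbers stand for weaker inhibition and lower numbers for stronger inhibition
Compound 2 `CC1(C)CCc2c(ccc(C(=O)/C=C/c3ccc(OCc4cn(Cc5ccc([N+](=O)[O-])cc5)nn4)cc3)c2O)O1` gives 69900 nM in this assay

Among the compounds with values here, compound 2 stands level with the only other measured compound. Compound 3 `CCCCCn1cc(COc2ccc(/C=C/C(=O)c3ccc4c(c3O)CCC(C)(C)O4)cc2)nn1` carries butyl in place of 4-nitrophenyl on a saturated chain carbon bound to an aromatic nitrogen and has not yet been measured. Within the data shown here, one measured step bears on this change, since it also swapped the group on an aromatic nitrogen a 1.3-fold lower number from compound 1 to compound 2 (0.12 log units; within the scatter) and stayed within the scatter. Among the measured compounds shown here, no measured compound has a ring-free chain there, so the evidence is thin. In this assay the expected step is none beyond the scatter (estimated as a 1.1-fold higher number from compound 2 to compound 3 (0.03 log units; within the scatter)). The estimate for compound 3 is 75000 nM (expected range 32000 nM to 170000 nM).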

Compound 3, half-maximal inhibitory concentration: 9820 nM
The estimate for compound 3 lay 7.6-fold (0.88 log units) above the measured number, outside the stated range (below it).
By their numbers in this assay, from the lowest: compound 3; then compounds 2 and 1 (each within the scatter of the next).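

In this assay, the group on the aromatic nitrogen turns out to matter: pentyl gives a clear drop from 4-nitrobenzyl (a 7.1-fold lower number from compound 2 to compound 3 (0.85 log units; beyond the scatter)) and from 4-acetylphenyl (a 9.3-fold lower number from compound 1 to compound 3 (0.97 log units; beyond the scatter)). The two ring-bearing groups sit within the scatter of each other, and the ring-free chain alone stands apart, with stronger inhibition. Nothing available explains this difference.

From the compounds shown here alone, whether a longer chain, or a chain ending in an amine or a carboxylic acid, would lower the number further remains open. So does whether any other ring-free group would behave like pentyl.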